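This account rests on a few compounds, and the source may have more. Where it says the series, first, only, none or still open, it means among the compounds named here.

Measured compounds:
Compound 1 `Cc1ccc([C@@H]2C[C@H](O)Cc3cc(Cl)ccc3N2)s1` – > 2040000 nM
Compound 2 `Cc1ccsc1[C@@H]1C[C@H](O)Cc2cc(Cl)ccc2N1` – 181000 nM
Compound 3 `Cc1ccsc1[C@@H]1C[C@H](O)Cc2cc(OC(F)(F)F)ccc2N1` – 89700 nM

In an ADME assay on THP-1 cells (Homo sapiens) for cytotoxicity (a lower number here means that less compound is tolerated, a higher number that more compound is tolerated), compound 2 gives the highest of the two real numbers. Its nearest neighbour is compound 3, and the step of a 2.0-fold lower number from compound 2 to compound 3 (0.30 log units; within the scatter) stays within the scatter, so the two cannot be told apart. Compound 1 reaches only a limit of this assay the limit of > 2040000 nM in this assay, at which 1 of the 3 values shown sits, rather than a number.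

Compound 4 `Cc1ccc([C@@H]2C[C@H](O)Cc3cc(Cl)ccc3N2)o1` has not been measured in this assay. It differs from compound 2 in one place: 5-methylfuran-2-yl in place of 3-methylthiophen-2-yl on a saturated ring carbon. Within the data shown here, the one measured step that bears on this site is an at least 11-fold lower number from compound 1 to compound 2 (1.05 log units; beyond the scatter), where moving the methyl on the thiophene changed the outcome by a large margin. Compound 4 carries the methyl in the same ring position as compound 1, with oxygen in the ring in place of sulfur. Since compound 1 sits at the limit (the limit of > 2040000 nM in this assay, at which 1 of the 3 values shown sits), compound 4 is expected to move back upward, possibly to the limit again.

Compound 4 is therefore estimated at 1200000 nM, between 250000 nM and 3000000 nM. That corresponds to an expected step of a 6.6-fold higher number from compound 2 to compound 4 (0.82 log units; beyond the scatter).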

Compound 4, half-maximal cytotoxic concentration: > 1080000 nM
Compound 4 gave a limit, no number (the forecaster's own chance of this, stated with the estimate: 45%); the middle value is on the limit's open side.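

In this assay, putting 5-methylfuran-2-yl in place of 3-methylthiophen-2-yl on this saturated ring carbon gives an at least 5.9-fold higher number from compound 2 to compound 4 (0.77 log units; beyond the scatter), so a thiophene is not needed for a high number here. Compound 4 gives a limit rather than a number, as does compound 1, so the step between these two cannot be read and no difference between the furan and the thiophene carrying the methyl in the same ring position can be stated: the limit of > 1080000 nM in this assay, at which 1 of the 4 values shown sits. Among the compounds shown, only compounds 2 and 3, which both carry 3-methylthiophen-2-yl, give real numbers.

On these data alone, how far the true values of compounds 1 and 4 lie past their limits remains open. Also open, as far as these compounds go, is how a 3-methylfuran-2-yl group or a plain phenyl ring would behave on this carbon.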